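The source may hold more compounds than are shown below. What is called first, only, known or untested is meant among the compounds shown, and "the series" means these compounds.

Working notes on the series. Going by the values given here, in a physicochemical assay for lipophilicity (a lower number here means a more polar compound, a higher number a more lipophilic compound), compound 1 (`CCNC(=O)COC(=O)c1ccccc1OC(C)=O`) gives 0.9, the higher of the two numbers so far. Compound 2 (`CC(=O)Oc1ccccc1C(=O)OC[S+](C)[O-]`) gives 0.141. Compound 3 (`CCCC(=O)OCOC(=O)c1ccccc1OC(C)=O`) has not yet been measured. The change that leads to it from compound 1 is (propylcarbonyl)oxy in place of ethylcarbamoyl on a saturated chain carbon bound to an oxygen next to a carbonyl group.

Among the compounds with values here, only one measured step bears on this place: a number 0.76 log units lower from compound 1 to compound 2 (beyond the scatter), a modest step that came with a smaller group entering. Within the data shown here, no measured pair shows the present replacement, so that step is only an indirect guide. Here the entering group is the larger one and has no hydrogen-bond donor, so a move in the opposite direction is expected in this assay, and a larger one than the step seen so far. The expected change is a number 1.30 log units higher from compound 1 to compound 3 (beyond the scatter), and this estimate rests on a single comparison. For compound 3 the estimated value is 2.2, with an expected range of 1.6 to 2.8.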

Compound 3, partition coefficient: 2.5
Compound 3: the middle estimate sits 0.30 log units below what was measured, within the range that was stated.
By their numbers in this assay, from the lowest: compound 2; then compound 1; then compound 3.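

In this assay, the saturated chain carbon bound to an oxygen next to a carbonyl group now shows movement in both directions: the earlier pair showed only a fall, whereas (propylcarbonyl)oxy in place of ethylcarbamoyl gives a number 1.60 log units higher from compound 1 to compound 3 (beyond the scatter) on the same core. The range at this place is also wider than the earlier pair showed, with (propylcarbonyl)oxy in place of the sulfur-containing group giving a number 2.36 log units higher from compound 2 to compound 3 (beyond the scatter) as the largest step among the three compounds. The ethylcarbamoyl to (propylcarbonyl)oxy replacement changes the heavy-atom count, the donor count and the acceptor count together, so this one step cannot separate those changes, and no measurement shown here accounts for its size.

Still open, going by these compounds, is how far the number follows the chain within the entering group, as a shorter acetyloxy group or a longer chain on the same ester could show. Also open, on these data alone, is where a carboxylic acid or an amine would fall at this place, and whether either would extend the range seen across these three compounds.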